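Cytotoxicity limits across a shared core, fourth compound pending

The compounds below may be only part of what the source reports. "The series", "measured", "known", "first", "only" and "open" are said of these compounds alone.

Compound 2 `O=C(CCc1ccc2c(c1)B(O)OC2)c1ccccc1` is the simplest member of the set. In an ADME assay on L929 cells (Mus musculus) for cytotoxicity, read by resazurin assay, with a stated time of 72 h (a higher number here means a weaker inhibitor, a lower number a stronger inhibitor), compound 2 gives > 10 ug/mL, a limit of the assay rather than a number. Compound 1 `COc1cccc(C(=O)CCc2ccc3c(c2)B(O)OC3)c1` differs from it by methoxy in place of hydrogen on an aromatic carbon. In this assay compound 1 gives > 10 ug/mL, again a limit. The step that the two limits leave unreadable from compound 2 to compound 1 therefore cannot be read in size. Compound 3 `COc1ccc(C(=O)/C=C/c2ccc3c(c2)B(O)OC3)cc1` carries a different core; the difference between the two cores is not broken down here. In this assay compound 3 gives > 10 ug/mL, also a limit. All three values sit at the limit of > 10 ug/mL in this assay, at which 3 of the 3 values shown sit, so no ordering among them can be stated.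

Compound 4 `COc1ccc(C(=O)/C=C/c2ccc3c(c2)B(O)OC3)cc1OC` is not yet measured. It differs from compound 3 by methoxy in place of hydrogen on an aromatic carbon. This is the same kind of change as that from compound 2 to compound 1, but the place differs: in compound 4 the entering group is ortho to a methoxy group, which is not so in compound 1. The step from compound 3 to compound 4 is expected to be a step that the limit leaves unreadable from compound 3 to compound 4, resting on the step that the two limits leave unreadable from compound 2 to compound 1, which gave no sign of a shift. Compound 4 is expected at 30 ug/mL, within 10 ug/mL to 100 ug/mL, and most likely reported only as a limit again.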

Compound 4, half-maximal inhibitory concentration: > 10 ug/mL
Compound 4: a limit, no number (the forecaster's own chance of this, stated with the estimate: 85%); the middle value does not contradict the limit.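

Compound 3 and compound 4 both stand as limits in this assay and not as numbers, so no new step can be read between them. The compounds shown leave open where any of the four would fall as a number in this assay and whether methoxy in place of hydrogen on an aromatic carbon moves that number at all.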